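The source may hold more compounds than are shown below. What is called first, only, known or untested is meant among the compounds shown, and "the series" means these compounds.

In an ADME assay on 184B5 cells (Homo sapiens) for cytotoxicity, read by MTT assay, with a stated time of 72 h (a higher number here means a weaker inhibitor of growth, a lower number a stronger inhibitor of growth), the measured compounds stand as follows:
compound 1 `N#C[Se]c1ccc(NC(=O)OCc2ccc([N+](=O)[O-])cc2)cc1` gives 18000 nM;
compound 2 `C=CCOC(=O)Nc1ccc([Se]C#N)cc1` gives 9800 nM;
compound 3 `CCCOC(=O)Nc1ccc([Se]C#N)cc1` gives 9100 nM.

Compound 3 holds the lowest of the three numbers, but its nearest neighbour, compound 2, sits within the scatter of it, and compound 1 also lies within the scatter, so the three measured compounds are not separated on this readout.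

Compound 4 `N#C[Se]c1ccc(NC(=O)OCc2ccccc2)cc1` has not yet been measured. It differs from compound 3 by phenyl in place of ethyl on a saturated chain carbon bound to an oxygen next to a carbonyl group. For the measured compounds named here, the only measured step at that same place is a 1.1-fold lower number from compound 2 to compound 3 (0.03 log units; within the scatter), a change too small to count. Compound 1, which carries a larger group than compound 3 on the shared core, gives a number within the scatter of compound 3. On that basis compound 4 is expected to show a step of a 1.3-fold higher number from compound 3 to compound 4 (0.12 log units; within the scatter), no larger than the scatter, leaning if anything toward the higher number of compound 1. The estimate for compound 4 is 12000 nM, with a range from 5500 nM to 26000 nM.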

Compound 4, concentration for total growth inhibition: 21900 nM
Compound 4: middle estimate off by 1.8-fold (0.26 log units), on the low side, and the stated range covers the measured number.
By their numbers in this assay, from the lowest: compounds 3, 2, 1 and 4 (each within the scatter of the next, the first and the last beyond it).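

In this assay, for the compounds shown here, phenyl in place of ethyl or vinyl on a saturated chain carbon bound to an oxygen next to a carbonyl group gives the first steps that lie beyond the scatter, with a 2.4-fold higher number from compound 3 to compound 4 (0.38 log units; beyond the scatter) and a 2.2-fold higher number from compound 2 to compound 4 (0.35 log units; beyond the scatter), both modest, whereas the earlier exchange at this place, a 1.1-fold lower number from compound 2 to compound 3 (0.03 log units; within the scatter), was too small to count. This position therefore does respond to the group it carries, though only modestly. Hydrogen in place of nitro on an aromatic carbon, by contrast, gives a 1.2-fold higher number from compound 1 to compound 4 (0.09 log units; within the scatter), so that change cannot be told apart from the scatter.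

The compounds shown leave open whether the higher number goes with the aromatic ring itself or with the larger group, as a cyclohexyl group or a longer chain at this place would be needed to separate the two. Nothing available explains why the number rises with phenyl.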